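The source may report more compounds than this note shows. Statements on the series, on what has been measured and on what is new or still open speak of the compounds shown alone.

Values in a functional assay on HT cells (Homo sapiens) for antiproliferative activity, read by fluorescence, with a stated time of 72 h (a lower number here means a stronger inhibitor of growth, a higher number a weaker inhibitor of growth), for the measured compounds

- compound 1 `CC(C)c1n[nH]c2c(NCc3ccc(-c4ccccn4)cc3)nc(SCCCN(C)C)nc12` gives 105 nM
- compound 2 `CC(C)c1n[nH]c2c(NCc3ccc(-c4ccccn4)cc3)nc(SC3CCCC3O)nc12` gives 567 nM

Compound 2 holds the higher of these two numbers. Compound 3 `CC(C)c1n[nH]c2c(NCc3ccc(-c4ccccn4)cc3)nc(SC[C@H](O)CN)nc12` differs from it on the sulfur, with 3-amino-2-hydroxypropyl in place of 2-hydroxycyclopentyl on a sulfur. Within the data shown here, the one measured step at this place, a 5.4-fold higher number from compound 1 to compound 2 (0.73 log units; beyond the scatter), is modest and beyond the scatter. Compound 3, like compound 1, carries an open chain with an amino group, so part of that step is expected to be recovered. The expected change is a 2.5-fold lower number from compound 2 to compound 3 (0.39 log units; beyond the scatter), a lower number. For compound 3 the estimated value is 230 nM, with an expected range from 90 nM to 600 nM.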

Compound 3, concentration for 50% growth inhibition: 63 nM
Beside the measured number, compound 3's estimate is 3.7-fold (0.56 log units) above it; the whole stated range lies above it.
By their numbers in this assay, from the lowest: compounds 3 and 1 (each within the scatter of the next); then compound 2.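

At this sulfur, 3-amino-2-hydroxypropyl in place of 2-hydroxycyclopentyl in this assay gives a clear gain (a 9.0-fold lower number from compound 2 to compound 3 (0.95 log units; beyond the scatter)). Compound 3 and compound 1 cannot be told apart (a 1.7-fold lower number from compound 1 to compound 3 (0.22 log units; within the scatter)), so among these three compounds both open chains with an amino group stand apart from the carbon ring, and no compound goes against this. No available measurement explains the difference.

Going by these compounds, it remains open what the hydroxyl and the defined stereocentre of compound 3 contribute. A plain primary amine chain without the hydroxyl, the opposite stereoisomer and a carboxylic acid at this sulfur also remain untested in the compounds shown.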